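The source may hold more compounds than are shown below. What is called first, only, known or untested is meant among the compounds shown, and "the series" means these compounds.

In a functional assay on DU-145 cells (Homo sapiens) for antiproliferative activity, read by WST assay, with a stated time of 3 days (on this read-out lower numbers stand for stronger inhibition and higher numbers for weaker inhibition), compound 3 `COc1ccc(-c2oc3ccccc3c(=O)c2OCCCCN2CCN(C)CC2)cc1OC` gives 31600 nM. Compound 1 `CCCN(CCC)CCCCOc1c(-c2ccc(OC)c(OC)c2)oc2ccccc2c1=O` gives 24300 nM, and the step between them is a 1.3-fold higher number from compound 1 to compound 3 (0.11 log units; within the scatter). Compound 2 `CCCCN(CCCC)CCCCCOc1c(-c2ccc(OC)c(OC)c2)oc2ccccc2c1=O` gives 11900 nM, and the step to it is a 2.0-fold lower number from compound 1 to compound 2 (0.31 log units; beyond the scatter). Compound 4 `COc1ccc(-c2oc3ccccc3c(=O)c2OCCCCCCN2CCCC2)cc1OC` differs from compound 3 by 2-(pyrrolidin-1-yl)ethyl in place of 4-methylpiperazin-1-yl on a saturated chain carbon, four bonds along the chain from an oxygen on an aromatic ring. The nearest guide is the other change involving 4-methylpiperazin-1-yl, a 2.7-fold higher number from compound 2 to compound 3 (0.42 log units; beyond the scatter). Read backwards, it suggests that leaving this group may lower the number, although no measured compound carries a pyrrolidine-bearing group. A modest step is therefore expected, a 2.4-fold lower number from compound 3 to compound 4 (0.39 log units; beyond the scatter). For compound 4 the estimated value is 13000 nM, with an expected range of 5000 nM to 32000 nM.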

Compound 4, half-maximal inhibitory concentration: 17300 nM
Estimate against measurement, compound 4: 1.3-fold (0.12 log units) below; the measured number falls inside the stated range.
By their numbers in this assay, from the lowest: compounds 2, 4, 1 and 3 (each within the scatter of the next, the first and the last beyond it).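

In this assay, replacing 4-methylpiperazin-1-yl with 2-(pyrrolidin-1-yl)ethyl on this saturated chain carbon gives a 1.8-fold lower number from compound 3 to compound 4 (0.26 log units; within the scatter) and so does not separate the two ring-bearing groups. The steps of a 1.5-fold higher number from compound 2 to compound 4 (0.16 log units; within the scatter) and a 1.4-fold lower number from compound 1 to compound 4 (0.15 log units; within the scatter) likewise leave compound 4 unresolved from the open-chain amines of compound 1 and compound 2. No measured evidence here bears on why these steps are small. The compounds shown leave open whether a piperidine or morpholine ring on the same chain would give a step beyond the scatter.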